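Isopropyl ester in place of the acyloxymethyl ester

The source may hold more compounds than are shown below. What is called first, only, known or untested is meant among the compounds shown, and "the series" means these compounds.

Compound 1 `CC(C)C(=O)OCOC(=O)C1=C(S[C@@H]2CN[C@H](C(=O)Nc3cccc(C(=O)O)c3)C2)[C@H](C)[C@@H]2[C@@H]([C@@H](C)O)C(=O)N12` is the reference point for this step. In an ADME assay for metabolic stability, read by LC-MS, with a stated time of 3 h, at pH 6.5, tested at 50 uM (on this read-out higher numbers stand for a more stable compound and lower numbers for a less stable compound), compound 1 gives > 95%, which is a limit of the assay and not a number. Going by the values given here, the one measured neighbour, compound 2 `CC(C)C(=O)OCOC(=O)C1=C(S[C@@H]2CN[C@H](C(=O)Nc3cccc(C(=O)OCOC(=O)C(C)C)c3)C2)[C@H](C)[C@@H]2[C@@H]([C@@H](C)O)C(=O)N12`, also sits at the limit: in this assay compound 2 gives > 95%. The step that the two limits leave unreadable from compound 1 to compound 2 cannot be read, since (the limit of > 95% in this assay, at which 2 of the 2 values shown sit). Compound 3 `CC(C)OC(=O)C1=C(S[C@@H]2CN[C@H](C(=O)Nc3cccc(C(=O)O)c3)C2)[C@H](C)[C@@H]2[C@@H]([C@@H](C)O)C(=O)N12` carries the change (isopropyl in place of ((isopropylcarbonyl)oxy)methyl on an oxygen next to a carbonyl group). Among the compounds with values here, no measured step bears on this change, so the numbers give no direction beyond the limit itself. With both measured compounds at the limit, compound 3 is expected to remain there as well, the step that the limit leaves unreadable from compound 1 to compound 3 being no more than scatter. The estimate for compound 3 in this assay is 96%, with a range from 87% to 99%.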

Compound 3, percent of the compound remaining: > 95%
Compound 3: only a limit was reported (the forecaster's own chance of this, stated with the estimate: 80%); the middle value is on the limit's open side.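

Compound 3, like compound 1, reads only as a limit of the assay, so no step from compound 1 to compound 3 can be read: the limit of > 95% in this assay, at which 3 of the 3 values shown sit.

Whether isopropyl and ((isopropylcarbonyl)oxy)methyl differ at all in this assay stays open, since the compounds shown give no value off the limit.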